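Swapping a benzyl for a phenoxy group: expected permeability

A few compounds are considered here, and "the series" means these few. Any claim that something is new, unique, unknown or untested is made for them only; others in the source may bear on it.

Measured compounds:
compound 1 `COc1ccc(F)cc1CNCCCNc1ccnc2cc(Cc3cc(C)cc(C)c3)ccc12`, 23 10^-6 cm/s
compound 2 `COc1cccc(CNCCCNc2ccnc3cc(Oc4ccc(Cl)cc4)ccc23)c1O`, 317 10^-6 cm/s
compound 3 `Cc1cc(C)cc(Cc2ccc3c(NCCCNCc4ccco4)ccnc3c2)c1`, 23 10^-6 cm/s

In an ADME assay for permeability, using PAMPA, with a stated time of 30 min, at pH 7.4 (on this read-out higher numbers stand for higher permeability and lower numbers for lower permeability), compound 1 gives 23 10^-6 cm/s, level with compound 3 and together with it the lowest of the three numbers; compound 2 stands far from both, and compound 2 gives 317 10^-6 cm/s. Within the data shown here, the one step of a single change among the measured compounds, no change at the digits printed from compound 1 to compound 3 (within the scatter), concerns the group on the chain carbon bound to the amine nitrogen and not the part of the molecule altered here.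

Compound 4 `COc1ccc(F)cc1CNCCCNc1ccnc2cc(Oc3ccc(C(C)(C)C)cc3)ccc12` differs from compound 1 at the core: 4-(tert-butyl)phenoxy in place of 3,5-dimethylbenzyl on an aromatic carbon. Among the measured compounds shown here, no measured step isolates such a swap. Compound 2, which also carries a phenoxy group on the core, shows a much higher number than compound 1, but it differs from compound 1 in a second place as well, so the comparison is only suggestive.

A moderate rise is therefore expected, a 3.0-fold higher number from compound 1 to compound 4 (0.48 log units; beyond the scatter), with wide uncertainty. Compound 4 is estimated at 70 10^-6 cm/s, between 20 10^-6 cm/s and 250 10^-6 cm/s.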

Compound 4, apparent permeability: 317 10^-6 cm/s
Compound 4: middle estimate off by 4.5-fold (0.66 log units), on the low side; measured number outside the range, above it.
By their numbers in this assay, from the lowest: compounds 1 and 3 (each within the scatter of the next); then compounds 2 and 4 (each within the scatter of the next).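

In this assay, putting 4-(tert-butyl)phenoxy in place of 3,5-dimethylbenzyl on this aromatic carbon of the core gives a 14-fold higher number from compound 1 to compound 4 (1.14 log units; beyond the scatter) as a large step, so this position can move the number strongly. Among these compounds, the only earlier single change, no change at the digits printed from compound 1 to compound 3 (within the scatter) on the amine side chain, left the number within the scatter. The new step changes the linking atom and the ring's substituents together, and nothing measured here bears on why the number rises.

Still open, as far as these compounds go, is which part of the swap carries the step: the oxygen link or the tert-butyl group. An unsubstituted phenoxy and a 4-(tert-butyl)benzyl group at this position on the core of compound 1 would pull those two parts apart.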